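Aryl-to-carbamoylmethyl swap on the triazole nitrogen

The source may hold more compounds than are shown below. What is called first, only, known or untested is meant among the compounds shown, and "the series" means these compounds.

Measured values in a functional assay on U-937 cells (Homo sapiens) for cytotoxicity, read by MTT assay, with a stated time of 24 h; a higher number here means a weaker inhibitor, a lower number a stronger inhibitor:
compound 1 `Nc1nn(Cc2cn(-c3ccc(F)c(Cl)c3)nn2)c2nc(-c3ccccc3)cc(C(F)(F)F)c12`: 99.1 ug/mL
compound 2 `Nc1nn(Cc2cn(-c3cccc(Cl)c3)nn2)c2nc(-c3ccccc3)cc(C(F)(F)F)c12`: 32.4 ug/mL
compound 3 `Cc1c(Br)cccc1-n1cc(Cn2nc(N)c3c(C(F)(F)F)cc(-c4ccccc4)nc32)nn1`: 97.2 ug/mL

Compound 3 stands second highest of the measured values. Its nearest neighbour is compound 1, with a 1.0-fold lower number from compound 1 to compound 3 (0.01 log units; within the scatter); its furthest is compound 2, with a 3.0-fold higher number from compound 2 to compound 3 (0.48 log units; beyond the scatter).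

Compound 4 `Nc1nn(Cc2cn(CC(=O)Nc3ccc(F)cc3Br)nn2)c2nc(-c3ccccc3)cc(C(F)(F)F)c12` is not yet measured. Relative to compound 3 the change is ((2-bromo-4-fluorophenyl)carbamoyl)methyl in place of 3-bromo-2-methylphenyl on an aromatic nitrogen.

Among the compounds with values here, two measured steps touch the same position: the step from compound 1 to compound 3 and the step from compound 2 to compound 3, both exchanging one aryl group for another on that nitrogen. One was within the scatter, the other modest. The step of a 3.1-fold lower number from compound 1 to compound 2 (0.49 log units; beyond the scatter) altered a single substituent on that aryl and was also modest. Within the data shown here, no measured pair exchanges an aryl group for a carbamoylmethyl chain, so the present change is larger than anything covered. On that basis the expected step is a 1.1-fold lower number from compound 3 to compound 4 (0.06 log units; within the scatter), within the scatter. Compound 4 is estimated at 85 ug/mL, with a range from 35 ug/mL to 160 ug/mL.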

Compound 4, half-maximal inhibitory concentration: 98.3 ug/mL
Compound 4: middle estimate off by 1.2-fold (0.06 log units), on the low side, and the stated range covers the measured number.
By their numbers in this assay, from the lowest: compound 2; then compounds 3, 4 and 1 (each within the scatter of the next).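

In this assay, replacing an aryl group on the aromatic nitrogen with the ((2-bromo-4-fluorophenyl)carbamoyl)methyl chain gives a 1.0-fold higher number from compound 3 to compound 4 (0.00 log units; within the scatter) and a 1.0-fold lower number from compound 1 to compound 4 (0.00 log units; within the scatter) even though the entering group adds a carbonyl and an amide hydrogen, so a directly attached aryl group is not needed to give numbers at this level. Compound 2 goes against any reading of the position as indifferent, with a 3.0-fold higher number from compound 2 to compound 4 (0.48 log units; beyond the scatter) and its 3-chlorophenyl group keeping the lowest number of the set. Nothing measured here explains why the number holds across this change or why compound 2 stands apart.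

The chain and its 2-bromo-4-fluorophenyl end enter together, so their contributions remain unseparated. A 3-chlorophenyl group carried on the same carbamoylmethyl chain would test this, and a carboxylic acid or an amine in place of the anilide would show whether the aryl end matters at all.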